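Azetidine oxadiazole amides: step from amide to urea

The source may report more compounds than this note shows. Statements on the series, on what has been measured and on what is new or still open speak of the compounds shown alone.

compound 1 `O=C(C1CCCO1)N1CC(c2nc(-c3cccc(Cl)c3)no2)C1` gives 890 nM in an assay on HEK293 cells for negative allosteric modulation of metabotropic glutamate receptor 5 (Homo sapiens), read by FLIPR; on this read-out lower numbers stand for stronger inhibition and higher numbers for weaker inhibition
compound 2 `O=C(C1CCC1)N1CC(c2nc(-c3cccc(Cl)c3)no2)C1` gives 1500 nM in this assay

Among the compounds with values here, compound 2 stands at the highest of the two numbers; its only neighbour is compound 1, and the step of a 1.7-fold higher number from compound 1 to compound 2 (0.23 log units; within the scatter) lies within the scatter. Compound 3 `CC1CCN(C(=O)N2CC(c3nc(-c4cccc(Cl)c4)no3)C2)CC1` differs from compound 2 in one place: 4-methylpiperidin-1-yl in place of cyclobutyl on a carbonyl carbon. Within the data shown here, the single measured step at this carbonyl carbon exchanged one ring for another without moving the number beyond the scatter, and no measured compound carries the entering group. For compound 3 in this assay no step beyond the scatter is therefore expected, a 1.7-fold lower number from compound 2 to compound 3 (0.22 log units; within the scatter). Compound 3 is estimated at 900 nM, in the range 250 nM to 4000 nM.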

Compound 3, half-maximal inhibitory concentration: > 10000 nM
Compound 3: only a limit was reported; the forecaster's own chance of this, stated with the estimate: 5%; at least 11-fold (1.04 log units) between middle value and limit.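

At this carbonyl carbon the group is not interchangeable: 4-methylpiperidin-1-yl gives an at least 6.6-fold higher number from compound 2 to compound 3 (0.82 log units; beyond the scatter) and an at least 11-fold higher number from compound 1 to compound 3 (1.05 log units; beyond the scatter), both towards weaker inhibition, while the earlier ring exchange stayed within the scatter. Compound 3 is known only as a limit of the assay: the limit of > 10000 nM in this assay, at which 1 of the 3 values shown sits. As far as these compounds go, the true size of both steps therefore remains unknown beyond the lower bounds printed with them.

Still open, from the compounds shown here alone, is whether the step follows from the methyl, the six-membered ring or the nitrogen attached to the carbonyl carbon. Piperidin-1-yl and pyrrolidin-1-yl would separate these.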